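The source may report more compounds than this note shows. Statements on the series, on what has been measured and on what is new or still open speak of the compounds shown alone.

In a functional assay on KB cells (Homo sapiens) for cytotoxicity, read by sulforhodamine B assay (on this read-out lower numbers stand for stronger inhibition and higher numbers for weaker inhibition), compound 1 (`Cc1cc(O)c(C=O)c2c1C(=O)Oc1c(O)c3c(c(C)c1O2)C(=O)CC(C)(C)O3`) gives 25.9 ug/mL and compound 2 (`Cc1cc(O)c(C=O)c2c1C(=O)Oc1c(cc3c(c1C)C(=O)CC(C)(C)O3)O2`) gives 37.1 ug/mL. These two values lie within the scatter of each other, so compound 1 is not separated from compound 2. Compound 3 (`Cc1c2c(c(O)c3c1C(=O)CC(C)(C)O3)OC(=O)c1c(C)c(Cl)c(O)c(C=O)c1O2`) carries chloro in place of hydrogen on an aromatic carbon of compound 1, ortho to a hydroxy group and ortho to a methyl group: chloro in place of hydrogen on an aromatic carbon. Going by the values given here, no measured step covers this change, so only a small shift toward lower numbers in this assay, likely within the scatter, is expected. The estimated step is a 1.4-fold lower number from compound 1 to compound 3 (0.16 log units; within the scatter). For compound 3 the estimated value is 18 ug/mL, with an expected range of 7 ug/mL to 42 ug/mL.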

Compound 3, half-maximal inhibitory concentration: 37.9 ug/mL
The estimate for compound 3 lay 2.1-fold (0.32 log units) below the measured number; low and high end bracket the measured number.
By their numbers in this assay, from the lowest: compounds 1, 2 and 3 (each within the scatter of the next).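

In this assay, chloro in place of hydrogen on an aromatic carbon, ortho to a hydroxy group and ortho to a methyl group, gives a 1.5-fold higher number from compound 1 to compound 3 (0.17 log units; within the scatter), so hydrogen and chloro are not separated at this position. The position therefore accepts a chloro group without a step beyond the scatter in this read-out. Nothing available bears on the reason for this result. Going by these compounds, whether bromo, methoxy or an amine at this position would separate from hydrogen remains open. So does whether a step beyond the scatter is possible here at all.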